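The source may report more compounds than this note shows. Statements on the series, on what has been measured and on what is new or still open speak of the compounds shown alone.

Measured compounds:
- compound 1 `Nc1ccn([C@@H]2O[C@@H](CO)C=C2F)c(=O)n1`: > 100000 nM
- compound 2 `Nc1nc(=O)n([C@@H]2O[C@@H](CO)C=C2F)cc1F`: > 100000 nM
- compound 3 `Nc1ncnc2c1ncn2[C@@H]1O[C@@H](CO)C=C1F`: > 100000 nM

In a functional assay on CCRF-CEM cells (Homo sapiens) for inhibition (on this read-out higher numbers stand for weaker inhibition and lower numbers for stronger inhibition), compound 1 gives > 100000 nM, a limit of the assay and not a number. Compound 2 gives > 100000 nM, also a limit. Compound 3 gives > 100000 nM, again a limit. All three sit at the limit of > 100000 nM in this assay, at which 3 of the 3 values shown sit. Compound 2 differs from compound 1 by fluoro in place of hydrogen on an aromatic carbon, and the step that the two limits leave unreadable from compound 1 to compound 2. The difference between the cores of compound 1 and compound 3 is not broken down here.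

Compound 4 `Nc1nc(F)nc2c1ncn2[C@@H]1O[C@@H](CO)C=C1F`, not yet measured, differs from compound 3 by fluoro in place of hydrogen on an aromatic carbon. This is the same kind of change as from compound 1 to compound 2, but the place differs: here the fluoro enters between two ring nitrogen atoms, meta to a fused ring, meta to an amino group and para to a fused ring, whereas in compound 2 it enters ortho to an amino group, two atoms from the ring nitrogen.

For compound 4 a step of a number no higher from compound 3 to compound 4 (the limit leaves the size open) is expected. This rests on compound 3, which gives > 100000 nM, a limit. The earlier step that the two limits leave unreadable from compound 1 to compound 2 gives no readable size to carry over. Compound 4 is estimated at 100000 nM, between 30000 nM and 300000 nM, most probably reported again as a limit.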

Compound 4, half-maximal inhibitory concentration: > 100000 nM
Compound 4 was reported as a limit; the forecaster's own chance of this, stated with the estimate: 85%; the middle value sits exactly at the limit.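

The step from compound 3 to compound 4 cannot be read, as both values are limits and not numbers. The compounds shown leave open whether fluoro in place of hydrogen on an aromatic carbon changes inhibition at all, since all share one limit: the limit of > 100000 nM in this assay, at which 4 of the 4 values shown sit.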